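The compounds below may be only part of what the source reports. "The series", "measured", "known", "first", "only" and "open" are said of these compounds alone.

Measured compounds:
- compound 1, `O=C(O)CCC/C=C\C[C@H]1[C@@H]2CCC(C2)[C@@H]1NS(=O)(=O)c1ccc([N+](=O)[O-])cc1`: 1400 nM
- compound 2, `O=C(O)CCC/C=C\C[C@H]1[C@@H]2CCC(C2)[C@@H]1NS(=O)(=O)CCCc1ccccc1`: 14000 nM
- compound 3, `O=C(O)CCC/C=C\C[C@H]1[C@@H]2CCC(C2)[C@@H]1NS(=O)(=O)c1ccc(O)cc1`: 500 nM

All three were tested in a functional assay (plasma) for inhibition, with Oryctolagus cuniculus as the target; on this read-out higher numbers stand for weaker inhibition and lower numbers for stronger inhibition. Compound 1 stands second highest of the three numbers; its nearest neighbour is compound 3, reached by a 2.8-fold lower number from compound 1 to compound 3 (0.45 log units; beyond the scatter), and its furthest is compound 2, reached by a 10-fold higher number from compound 1 to compound 2 (1.00 log units; beyond the scatter). Between the other two lies a 28-fold lower number from compound 2 to compound 3 (1.45 log units; beyond the scatter).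

The new compound 4, `O=C(O)CCC/C=C\C[C@H]1[C@@H]2CCC(C2)[C@@H]1NS(=O)(=O)c1ccc(Cl)cc1`, differs from compound 1 in one place: chloro in place of nitro on an aromatic carbon. Within the data shown here, the step that bears most directly on it is the one from compound 1 to compound 3, where the group on the same aromatic carbon was exchanged and the number moved by a 2.8-fold lower number from compound 1 to compound 3 (0.45 log units; beyond the scatter). The steps involving compound 2 exchange the whole group on the sulfonyl sulfur and are less comparable. Among the measured compounds shown here, a para exchange on this ring therefore looks like a modest move at most, and with no measured chloro analogue the direction is open; a step within or just beyond the scatter, more likely toward a lower number, is expected as a 1.8-fold lower number from compound 1 to compound 4 (0.24 log units; within the scatter). For compound 4 the estimate in this assay is 800 nM, between 250 nM and 2500 nM.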

Compound 4, half-maximal inhibitory concentration: 300 nM
Estimate against measurement, compound 4: 2.7-fold (0.43 log units) above, and the stated range covers the measured number.
By their numbers in this assay, from the lowest: compounds 4 and 3 (each within the scatter of the next); then compound 1; then compound 2.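

In this assay the second replacement of nitro on this aromatic carbon, para to a large group, again lowers the number, here with chloro in place of nitro (a 4.7-fold lower number from compound 1 to compound 4 (0.67 log units; beyond the scatter)), so the earlier step to hydroxy no longer stands alone. Chloro and hydroxy cannot be told apart at this place (a 1.7-fold lower number from compound 3 to compound 4 (0.22 log units; within the scatter)), and compound 1, with its nitro group, now stands apart from both of them. The 4-chlorophenyl group also widens the gap to the 3-phenylpropyl group on the sulfonyl sulfur (a 47-fold lower number from compound 2 to compound 4 (1.67 log units; beyond the scatter)), and among the four compounds that chain still gives the highest number.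

As far as these compounds go, whether an amine, a methoxy group or a carboxylic acid on this same aromatic carbon would fall with chloro and hydroxy or with nitro remains open, as does whether a shorter chain on the sulfonyl sulfur would behave like the 3-phenylpropyl group. Nothing available here accounts for the difference between nitro and the two other groups.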